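The source may hold more compounds than are shown below. What is called first, only, known or untested is meant among the compounds shown, and "the series" means these compounds.

Compound 3 `COc1cccc(OC)c1OCCNCCOc1ccccc1OCc1ccc([N+](=O)[O-])cc1` gives 43600 nM in a functional assay on PC-3 cells (Homo sapiens) for cytotoxicity, read by sulforhodamine B assay (on this read-out higher numbers stand for weaker inhibition of growth and lower numbers for stronger inhibition of growth), the highest number among the three measured compounds. Compound 1 `COc1cccc(OC)c1OCCNCCOc1ccccc1OCc1ccccc1Cl` gives 17800 nM in this assay, and compound 2 `COc1cccc(OC)c1OCCNCCOc1ccccc1OCc1ccccc1C` gives 33900 nM. The steps between them are small: a 1.9-fold higher number from compound 1 to compound 2 (0.28 log units; within the scatter), a 2.4-fold higher number from compound 1 to compound 3 (0.39 log units; beyond the scatter) and a 1.3-fold higher number from compound 2 to compound 3 (0.11 log units; within the scatter). Compound 4 `COc1ccc(COc2ccccc2OCCNCCOc2c(OC)cccc2OC)cc1` differs from compound 3 by methoxy in place of nitro on an aromatic carbon. For the measured compounds named here, no measured step shows this exact exchange of methoxy for nitro; the only steps that touch the same benzyl group are a 2.4-fold higher number from compound 1 to compound 3 (0.39 log units; beyond the scatter) and a 1.3-fold higher number from compound 2 to compound 3 (0.11 log units; within the scatter), both of which show that swapping one substituted benzyl group for another moves this assay only modestly. On that basis the step is expected to be small, a 1.4-fold lower number from compound 3 to compound 4 (0.13 log units; within the scatter), with a slight lean toward a lower number given that compound 3 already stands at the top of the range. The estimate for compound 4 in this assay is therefore 32000 nM, with a range from 14000 nM to 75000 nM.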

Compound 4, concentration for total growth inhibition: 34700 nM
Beside the measured number, compound 4's estimate is 1.1-fold (0.04 log units) below it; the measured number falls inside the stated range.
By their numbers in this assay, from the lowest: compounds 1, 2, 4 and 3 (each within the scatter of the next, the first and the last beyond it).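

In this assay, methoxy in place of nitro on this aromatic carbon gives a 1.3-fold lower number from compound 3 to compound 4 (0.10 log units; within the scatter) and so leaves the read-out unchanged within the scatter, although the exchanged groups differ in size and atoms. The 4-methoxybenzyl group also cannot be separated from the benzyl groups of the other two compounds, with a 1.0-fold higher number from compound 2 to compound 4 (0.01 log units; within the scatter) and a 1.9-fold higher number from compound 1 to compound 4 (0.29 log units; within the scatter) as the steps. For the compounds shown here, this leaves a 2.4-fold higher number from compound 1 to compound 3 (0.39 log units; beyond the scatter) as the only step among the four compounds that lies beyond the scatter, and it is a modest one. Nothing at hand explains why these groups read so alike.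

As far as these compounds go, whether an amine or a carboxylic acid on this aromatic carbon would move the number out of this narrow band remains open. So does the effect of a longer chain in place of the benzyl group.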